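A few compounds are considered here, and "the series" means these few. Any claim that something is new, unique, unknown or untested is made for them only; others in the source may bear on it.

Measured so far in a functional assay on HCT-116 cells (Homo sapiens) for cytotoxicity, read by MTT assay, with a stated time of 72 h; a higher number here means a weaker inhibitor, a lower number a stronger inhibitor:
- compound 1 `N[C@H]1CC[C@H](Nc2c(C(=O)NCc3ccc(F)cc3)nc(N3CCCCS3(=O)=O)c3cccnc23)CC1`: > 10000 nM
- compound 2 `C[C@@H](Nc1c(C(=O)NCc2ccc(F)cc2)nc(Br)c2cccnc12)c1ccccc1`: > 20000 nM

Neither entry is an exact number. Compound 1 stands at a limit of this assay, > 10000 nM, so its real potency is not known. Compound 2 also stands at a limit, > 20000 nM. Within the data shown here, with two limits and no exact value, the two compounds cannot be ranked against each other, and no measured step is available as a guide.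

The next compound is compound 3 `N[C@H]1CC[C@H](Nc2c(C(=O)NCc3ccc(F)cc3)nc(N3CCCCC3)c3cccnc23)CC1`, which keeps the shared core and the (4-aminocyclohexyl)amino group of compound 1. The change is a group of 6 heavy atoms (5 carbon, 1 nitrogen; one six-membered non-aromatic ring with 1 hetero atom) in place of a group of 8 heavy atoms (4 carbon, 1 nitrogen, 2 oxygen, 1 sulfur; one six-membered non-aromatic ring with 2 hetero atoms), on an aromatic carbon. It sits on an aromatic carbon, next to the ring nitrogen, with piperidin-1-yl as the new group.

Among the measured compounds shown here, with no measured step to draw on, the expectation is for little change, perhaps slightly towards a stronger inhibitor. The expected step, an at least 1.2-fold lower number from compound 1 to compound 3 (0.09 log units; that floor lies within the scatter), is not clearly beyond the usual scatter, and the assay may again report only a limit. For compound 3 the estimated value is 8000 nM. The expected range for compound 3 runs from 2000 nM to 30000 nM.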

Compound 3, half-maximal inhibitory concentration: 8000 nM
Compound 3: middle estimate and measured number agree at the digits printed; the range from low to high includes it.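

In this assay compound 3 gives 8000 nM, the only exact number among the compounds shown, so this series can register a measurable value in this assay when piperidin-1-yl sits on the aromatic carbon next to the ring nitrogen. Putting piperidin-1-yl in place of the ring that holds sulfur and two oxygens gives an at least 1.2-fold lower number from compound 1 to compound 3 (0.09 log units; that floor lies within the scatter), so the change can be read only as a minimum step, and that minimum does not go beyond the usual scatter. The true size of the step could be small or much larger, and it stays unknown because compound 1 is recorded only as a limit: the limit of > 10000 nM in this assay, at which 1 of the 3 values shown sits.

From the compounds shown here alone, whether another group on this same carbon, such as morpholin-4-yl or a small open-chain amine like dimethylamino, would give a number clearly apart from that of compound 3 remains open. Compound 2 differs from compound 3 in more than one place, so the part played by the (4-aminocyclohexyl)amino group, taken alone, also remains unresolved.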